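Lactam series: a third methoxy added to compound 2

The source may report more compounds than this note shows. Statements on the series, on what has been measured and on what is new or still open speak of the compounds shown alone.

Compound 1 `COc1cc(/C=C/C2CC=CC(=O)O2)cc(OC)c1OC` gives 28.8 uM in a functional assay on NCI-H460 cells (Homo sapiens) for inhibition, read by sulforhodamine B assay, with a stated time of 48 h; a higher number here means a weaker inhibitor of growth, a lower number a stronger inhibitor of growth. Compound 2 `COc1ccc(/C=C/C2CC=CC(=O)N2)cc1OC` in this assay gives only a limit of the assay, > 964 uM. This value is the limit of > 964 uM in this assay, at which 1 of the 2 values shown sits. Taken together, the two values show compound 1 inhibiting growth at a far lower concentration than compound 2, but no single-change step joins them. Compound 3 `COc1cc(/C=C/C2CC=CC(=O)N2)cc(OC)c1OC` differs from compound 2 by methoxy in place of hydrogen on an aromatic carbon. Among the compounds with values here, no measured step of this kind exists here, so the step of an at least 2.7-fold lower number from compound 2 to compound 3 (0.44 log units; beyond the scatter) is expected to be small, at most modestly toward stronger inhibition. Compound 3 is estimated at 350 uM, within 60 uM to 1500 uM.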

Compound 3, concentration for growth inhibition (reported as GI): > 864 uM
Compound 3 was reported as a limit; the forecaster's own chance of this, stated with the estimate: 50%; middle value at least 2.4-fold (0.39 log units) away from the limit.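

In this assay compound 3 gives > 864 uM, a limit of the assay. The series now has its first readable single-change step, an at least 30-fold higher number from compound 1 to compound 3 (1.47 log units; beyond the scatter), with the nitrogen-containing ring group in place of the ring group holding two oxygens. The methoxy step between compound 2 and compound 3 cannot be read, as both values are limits.

Open, as far as these compounds go, is what this methoxy position does in the core of compound 1, which has a measured value. There, hydrogen, a hydroxyl or an amine in place of this methoxy would give a readable step.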